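The source may hold more compounds than are shown below. What is called first, only, known or untested is meant among the compounds shown, and "the series" means these compounds.

Of the compounds shown here, three of one series have been tested in a functional assay on PC-12 cells (Rattus norvegicus) for cytotoxicity, read by MTT assay, with stated times of 3 h and 2 h, tested at 20 uM; a higher number here means a stronger effect of the compound at the concentration tested, a lower number a weaker effect. Compound 1 `O=C(CCCCC1CCSS1)NCc1cn(CCCOc2ccc3ccc(=O)oc3c2)nn1` gives 42.2%, compound 2 `CC(=O)c1cc2ccc(OCCCn3cc(CNC(=O)CCCCC4CCSS4)nn3)cc2oc1=O` gives 39.8%, and compound 3 `COc1ccc(-c2cc3ccc(OCCCn4cc(CNC(=O)CCCCC5CCSS5)nn4)cc3oc2=O)cc1` gives 62%. Compound 3 stands highest of the three: a number 19.8 percentage points higher from compound 1 to compound 3 (beyond the scatter) and a number 22.2 percentage points higher from compound 2 to compound 3 (beyond the scatter), both beyond the scatter, whereas a number 2.4 percentage points lower from compound 1 to compound 2 (within the scatter) stays within it.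

Compound 4 `O=C(CCCCC1CCSS1)NCc1cn(CCCOc2ccc3cc(-c4ccc(Cl)c(Cl)c4)c(=O)oc3c2)nn1` has not yet been measured. It differs from compound 3 in one place: 3,4-dichlorophenyl in place of 4-methoxyphenyl on an aromatic carbon. Going by the values given here, the two steps that bear on this position, from compound 1 and from compound 2 to compound 3, both show that an aromatic ring at this carbon goes with a higher number; no measured step compares one aromatic ring with another there, so the size of the change from 4-methoxyphenyl to 3,4-dichlorophenyl is unknown. Compound 4 is therefore expected to keep most of the level of compound 3, with a step of a number 6 percentage points lower from compound 3 to compound 4 (within the scatter) that need not exceed the scatter. Compound 4 is estimated at 56% in this assay, in a range from 36% to 76%.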

Compound 4, a percentage reported as activity, at one concentration (the size of the read-out at that concentration, not a potency): 51.2%
For compound 4 the middle estimate is 4.8 percentage points above the measured one, within the range that was stated.
By their numbers in this assay, from the lowest: compounds 2, 1 and 4 (each within the scatter of the next, the first and the last beyond it); then compound 3.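

In this assay, the two aromatic rings at this carbon can be told apart (a number 10.8 percentage points lower from compound 3 to compound 4 (beyond the scatter)), so the outcome depends on what the ring carries and not only on a ring being there. The 3,4-dichlorophenyl ring stays clear of the acetyl compound (a number 11.4 percentage points higher from compound 2 to compound 4 (beyond the scatter)) but not of the parent with hydrogen (a number 9 percentage points higher from compound 1 to compound 4 (within the scatter)), so compound 4 goes against any reading that every aromatic ring here lifts the number beyond the scatter, as 4-methoxyphenyl does. No measurement at hand explains the gap between the two rings.

The change swaps the methoxy group and both chlorines at once, so the compounds shown do not say which of these matters, or whether one chlorine alone or a plain phenyl would sit nearer compound 3. From the compounds shown here alone, how a phenyl carrying an amine or a carboxylic acid would read at this carbon also remains open.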